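The source may hold more compounds than are shown below. What is called first, only, known or untested is meant among the compounds shown, and "the series" means these compounds.

Of the compounds shown here, three sharing one core have been measured so far. Compound 1 `COc1cc(/C=C/C(=O)c2cccc(NC(=O)c3cccs3)c2)ccc1O` carries a thiophen-2-yl group on the carbonyl carbon of its amide, and in a functional assay on SiHa cells (Homo sapiens) for inhibition (a lower number here means a stronger inhibitor, a higher number a weaker inhibitor), compound 1 gives 6.57 ug/mL. Compound 2 `COc1cc(/C=C/C(=O)c2cccc(NC(=O)c3cc(Cl)cc(Cl)c3)c2)ccc1O` has a 3,5-dichlorophenyl there instead, and compound 2 gives 17.7 ug/mL. Compound 3 `COc1cc(/C=C/C(=O)c2cccc(NC(=O)c3ccc(Cl)cc3Cl)c2)ccc1O` carries a 2,4-dichlorophenyl, and compound 3 gives 34.4 ug/mL, the highest of the three numbers; its nearest neighbour is compound 2, at a distance within the scatter, while compound 1 lies well below it.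

The next compound, compound 4 `COc1cc(/C=C/C(=O)c2cccc(NC(=O)c3ccccc3)c2)ccc1O`, differs from compound 3 in one place: phenyl in place of 2,4-dichlorophenyl on a carbonyl carbon.

For the measured compounds named here, no measured step swaps a dichlorophenyl for a plain phenyl, so the expectation rests on what is there. Putting a dichlorophenyl in place of thiophen-2-yl raised the number, a 2.7-fold higher number from compound 1 to compound 2 (0.43 log units; beyond the scatter) and a 5.2-fold higher number from compound 1 to compound 3 (0.72 log units; beyond the scatter), while moving the two chlorines between the two dichlorophenyl patterns changed little, a 1.9-fold higher number from compound 2 to compound 3 (0.29 log units; within the scatter). Since a phenyl without chlorines is, in size, closer to the thiophen-2-yl of compound 1 than to either dichlorophenyl, a drop in number is expected for compound 4, a 2.9-fold lower number from compound 3 to compound 4 (0.46 log units; beyond the scatter), though a step within the scatter cannot be ruled out. Compound 4 is therefore estimated at 12 ug/mL, with a likely range from 5 ug/mL to 30 ug/mL.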

Compound 4, half-maximal inhibitory concentration: 4.57 ug/mL
The estimate for compound 4 lay 2.6-fold (0.42 log units) above the measured number, outside the stated range (below it).
By their numbers in this assay, from the lowest: compounds 4 and 1 (each within the scatter of the next); then compounds 2 and 3 (each within the scatter of the next).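

In this assay the loss of both chlorines clearly lowers the number: going from 2,4-dichlorophenyl to phenyl gives a 7.5-fold lower number from compound 3 to compound 4 (0.88 log units; beyond the scatter) and going from 3,5-dichlorophenyl to phenyl gives a 3.9-fold lower number from compound 2 to compound 4 (0.59 log units; beyond the scatter) and so both chlorine patterns are weaker than plain phenyl here. Phenyl and thiophen-2-yl, by contrast, show no real difference on this carbonyl carbon, with a 1.4-fold lower number from compound 1 to compound 4 (0.16 log units; within the scatter) and so the higher numbers of compound 2 and compound 3 go with the chlorines rather than with replacing thiophen-2-yl by a six-membered ring. Nothing available explains why the chlorines have this effect.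

The compounds shown leave open whether a single chlorine on the phenyl already raises the number. They also leave open whether a methoxy group or an amine on that phenyl would bring it lower than in compound 4.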